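Removing the Aminoethoxy Side Chain from Compound 1

The compounds below may be only part of what the source reports. "The series", "measured", "known", "first", "only" and "open" are said of these compounds alone.

Of the compounds shown here, two have been measured in a functional assay on A549 cells (Homo sapiens) for inhibition, read by MTT assay, with a stated time of 48 h; a lower number here means a stronger inhibitor, a higher number a weaker inhibitor. Compound 1 `COc1ccc(N(C)c2nc(C)nc3ccccc23)cc1OCCN` gives 122 nM, the highest of the two numbers; compound 2 `C[Se]c1ccc(N(C)c2nc(C3CC3)nc3ccccc23)cc1` gives 13 nM. Compound 2 differs from compound 1 in more than one place, so the gap between them cannot be tied to a single change.

The next compound, compound 3 `COc1ccc(N(C)c2nc(C)nc3ccccc23)cc1`, arises from compound 1 by one change: hydrogen in place of 2-aminoethoxy on an aromatic carbon. The group that leaves sits ortho to a methoxy group and meta to a large group. Among the compounds with values here, no measured pair shows this change on its own, so there is nothing in the data from which its effect can be read.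

Within the data shown here, with no such step available, a modest change is expected, likely within or only slightly beyond the usual scatter, and the step from compound 1 to compound 3 is estimated at a 1.5-fold lower number from compound 1 to compound 3 (0.18 log units; within the scatter). Compound 3 is therefore expected to give about 80 nM, with a likely range from 25 nM to 300 nM.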

Compound 3, half-maximal inhibitory concentration: 3 nM
The estimate for compound 3 lay 27-fold (1.43 log units) above the measured number; measured number outside the range, below it.
By their numbers in this assay, from the lowest: compound 3; then compound 2; then compound 1.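

In this assay, within the data shown here, hydrogen in place of 2-aminoethoxy on this aromatic carbon, ortho to a methoxy group, gives a 41-fold lower number from compound 1 to compound 3 (1.61 log units; beyond the scatter) and so provides the first measured single-change step in this set. It shows that this position strongly affects the number and that, for compound 3, the 2-aminoethoxy group is not needed to reach a low value. No measurement here speaks to the cause of this step.

On these data alone, with only 2-aminoethoxy and hydrogen compared at this carbon, it remains open whether the ether oxygen, the chain length or the terminal amine matters most. A 2-hydroxyethoxy group, a plain methoxy group or a longer 3-aminopropoxy chain at the same place would help separate these possibilities.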